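A few compounds are considered here, and "the series" means these few. Any claim that something is new, unique, unknown or untested is made for them only; others in the source may bear on it.

For the measured compounds named here, compound 1 `Cc1ccc(-c2c(C)nn(-c3nc(-c4ccc(Cl)c(Cl)c4)c(SC(C)C)s3)c2C(=O)O)cc1` gives 3800 nM in a functional assay on BJAB cells (Homo sapiens) for antiproliferative activity, with a stated time of 4 days (a lower number here means that less compound is needed, a higher number that more compound is needed for the effect), the lowest of the three numbers so far. Compound 3 `Cc1nn(-c2nc(-c3ccc(Cl)c(Cl)c3)c(SC(C)C)s2)c(C(=O)O)c1-c1cccc(Cl)c1C` gives 5100 nM, and compound 2 `Cc1nn(-c2nc(-c3ccc(Cl)c(Cl)c3)c(SC(C)C)s2)c(C(=O)O)c1-c1cncnc1` gives 22000 nM; the gap between them, a 4.3-fold lower number from compound 2 to compound 3 (0.63 log units; beyond the scatter), lies beyond the scatter. Compound 4 `CNc1cc(-c2c(C)nn(-c3nc(-c4ccc(Cl)c(Cl)c4)c(SC(C)C)s3)c2C(=O)O)ccn1` differs from compound 1 in one place: 2-(methylamino)pyridin-4-yl in place of 4-methylphenyl on an aromatic carbon. The measured step that bears on it most is the change to another six-membered ring with hetero atoms, a 5.8-fold higher number from compound 1 to compound 2 (0.76 log units; beyond the scatter), whereas the change to a carbon-only ring, a 1.3-fold higher number from compound 1 to compound 3 (0.13 log units; within the scatter), stayed within the scatter. By analogy with the pyrimidin-5-yl step, a modest upward step is expected, a 2.1-fold higher number from compound 1 to compound 4 (0.32 log units; beyond the scatter). Compound 4 is therefore expected to give about 8000 nM in this assay, within a range from 3000 nM to 25000 nM.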

Compound 4, half-maximal effective concentration: 18000 nM
For compound 4 the middle estimate is 2.3-fold (0.35 log units) below the measured one; the range from low to high includes it.
By their numbers in this assay, from the lowest: compounds 1 and 3 (each within the scatter of the next); then compounds 4 and 2 (each within the scatter of the next).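

In this assay, a 4.7-fold higher number from compound 1 to compound 4 (0.68 log units; beyond the scatter) and a 3.5-fold higher number from compound 3 to compound 4 (0.55 log units; beyond the scatter), so a second ring with hetero atoms falls beyond the scatter of both carbon-only rings, and neither of the four compounds goes against this. Against the pyrimidin-5-yl ring, a 1.2-fold lower number from compound 2 to compound 4 (0.09 log units; within the scatter), so adding a hydrogen-bond donor on the ring does not separate the two. No evidence on the cause is available here. Open, going by these compounds, is whether a plain pyridin-4-yl ring, or a primary amine in place of the methylamino group, would give a number in the same range.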